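The source may hold more compounds than are shown below. What is called first, only, known or untested is meant among the compounds shown, and "the series" means these compounds.

Compound 1 `O=S(=O)(NCCNCc1ccc(-c2ccccc2)cc1)c1cc(C(F)(F)F)cc(C(F)(F)F)c1`: 2700 nM
Compound 2 `COc1ccc(CNCCCNS(=O)(=O)c2cc(C(F)(F)F)cc(C(F)(F)F)c2)cc1OC`: 2700 nM
Compound 3 `O=S(=O)(NCCCNCC1COc2ccccc2O1)c1cc(C(F)(F)F)cc(C(F)(F)F)c1`: 2200 nM

In a functional assay on HT-29 cells (Homo sapiens) for inhibition, read by MTT assay, with a stated time of 72 h (on this read-out higher numbers stand for weaker inhibition of growth and lower numbers for stronger inhibition of growth), the three measured compounds sit close together. Compound 2 gives 2700 nM, level with compound 1 at the digits shown, and its gap to compound 3 is a 1.2-fold lower number from compound 2 to compound 3 (0.09 log units; within the scatter), which is within the scatter. On the numbers shown, then, compound 2 is not separated from any other measured compound beyond the scatter.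

Compound 4 `COc1ccccc1CNCCCNS(=O)(=O)c1cc(C(F)(F)F)cc(C(F)(F)F)c1` has not yet been measured. It differs from compound 2 in one place: 2-methoxyphenyl in place of 3,4-dimethoxyphenyl on a saturated chain carbon bound to an amine nitrogen

Going by the values given here, only one measured step bears on this change, the one from compound 2 to compound 3, a 1.2-fold lower number from compound 2 to compound 3 (0.09 log units; within the scatter), which also swaps the group on a saturated chain carbon bound to an amine nitrogen, and it stays within the scatter. Among the compounds with values here, the shared core and the chain are kept unchanged, and the one comparison available shows that altering this group did not move the number beyond the scatter. The expectation for this assay is therefore no step beyond the scatter from compound 2 to compound 4, in either direction.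

Compound 4 is expected to give about 2700 nM, within a range from 1300 nM to 5600 nM. This estimate corresponds to an expected step of no change at the digits printed from compound 2 to compound 4 (within the scatter).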

Compound 4, concentration for 50% growth inhibition: 12000 nM
Estimate against measurement, compound 4: 4.4-fold (0.65 log units) below; measured number outside the range, above it.
By their numbers in this assay, from the lowest: compounds 3, 1 and 2 (each within the scatter of the next); then compound 4.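

In this assay the group on a saturated chain carbon bound to an amine nitrogen now proves able to move the number: 2-methoxyphenyl in place of 3,4-dimethoxyphenyl gives a 4.4-fold higher number from compound 2 to compound 4 (0.65 log units; beyond the scatter) and, in place of 2,3-dihydro-1,4-benzodioxin-2-yl, gives a 5.5-fold higher number from compound 3 to compound 4 (0.74 log units; beyond the scatter) on the same read-out. The earlier swap at this place, from compound 2 to compound 3, stayed within the scatter and suggested that the group could vary freely, whereas compound 4 shows that this freedom has limits, with weaker inhibition of growth arising from this single change while the shared core and chain stay the same. Nothing available here explains why 2-methoxyphenyl differs from the other two groups.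

The compounds shown leave open whether the weaker inhibition of growth goes with the methoxy group standing at the 2 position of the ring or with the loss of a second methoxy group. A 4-methoxyphenyl or a plain phenyl group at this place, on the same chain, would help to separate those two readings.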